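Swapping chloro for bromo in compound 1

The source may hold more compounds than are shown below. What is called first, only, known or untested is meant among the compounds shown, and "the series" means these compounds.

In a functional assay on T98G cells (Homo sapiens) for inhibition, read by MTT assay, with a stated time of 72 h (a lower number here means a stronger inhibitor, a higher number a weaker inhibitor), compound 1 `CC1(C)CC(NC(=S)Nc2ccc(C#N)cc2)c2cc(Cl)ccc2O1` gives 10000 nM and holds the lowest of the three numbers. Compound 2 `CC1(C)CC(NC(=S)Nc2ccccc2)c2cc(Cl)ccc2O1` stands at 37000 nM and compound 3 `CC1(C)CC(NC(=S)NCc2ccccc2)c2cc(Cl)ccc2O1` at 99000 nM on this scale. Compound 4 `CC1(C)CC(NC(=S)Nc2ccc(C#N)cc2)c2cc(Br)ccc2O1` is not yet measured. Among the compounds with values here, its one change from compound 1 is bromo in place of chloro on an aromatic carbon on the shared core, bromo in place of chloro on an aromatic carbon. The data show a 3.7-fold higher number from compound 1 to compound 2 (0.57 log units; beyond the scatter) and a 2.7-fold higher number from compound 2 to compound 3 (0.43 log units; beyond the scatter) and a 9.9-fold higher number from compound 1 to compound 3 (1.00 log units; beyond the scatter) but none of these modest steps changes the chloro. The expectation therefore rests on compound 1 at 10000 nM alone, with no step beyond the scatter expected. The estimated change is a 1.1-fold lower number from compound 1 to compound 4 (0.05 log units; within the scatter) in this assay overall. Compound 4 is expected at 9000 nM within an estimated range of 4500 nM to 20000 nM for now.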

Compound 4, half-maximal inhibitory concentration: 24000 nM
The estimate for compound 4 lay 2.7-fold (0.43 log units) below the measured number; the whole stated range lies below it.
By their numbers in this assay, from the lowest: compound 1; then compounds 4 and 2 (each within the scatter of the next); then compound 3.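

In this assay, within the data shown here, the halogen on the shared core proves to matter: bromo in place of chloro gives a 2.4-fold higher number from compound 1 to compound 4 (0.38 log units; beyond the scatter), a real step even though only one atom changes. The earlier steps shown here all left the chloro in place, so they could not show that this position responds to such a small swap. Nothing available explains the step.

On these data alone, whether a fluoro, a methyl or a methoxy group at this position would give a lower or a higher number remains open. So does whether the same swap would move compound 2 or compound 3 in the same direction.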